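A few compounds are considered here, and "the series" means these few. Any claim that something is new, unique, unknown or untested is made for them only; others in the source may bear on it.

Compound 1 `Clc1ccc(CSc2nnc(-c3cnccn3)o2)cc1` and compound 2 `Brc1ccc(CSc2nnc(-c3cnccn3)o2)cc1` share one core, while compound 3 `Clc1ccc(CSc2nnc(-c3cnccn3)s2)cc1` is built on a different core; the difference between the two cores is not broken down here. In a functional assay on HepG2 cells (Homo sapiens) for antiproliferative activity, read by MTT assay, with a stated time of 48 h (on this read-out higher numbers stand for weaker inhibition and lower numbers for stronger inhibition), compound 1 gives 11500 nM, compound 2 gives 13200 nM and compound 3 gives 6230 nM. The change from compound 1 to compound 2 is bromo in place of chloro on an aromatic carbon and its step is a 1.1-fold higher number from compound 1 to compound 2 (0.06 log units; within the scatter). Compound 4 `Brc1ccc(CSc2nnc(-c3cnccn3)s2)cc1` has not yet been measured; it differs from compound 3 by bromo in place of chloro on an aromatic carbon, the same change at the same place. Because this change earlier gave a 1.1-fold higher number from compound 1 to compound 2 (0.06 log units; within the scatter), a step of similar size is expected from compound 3 to compound 4 in this assay, namely a 1.1-fold higher number from compound 3 to compound 4 (0.06 log units; within the scatter). Compound 4 is therefore estimated at 7100 nM, with a likely range from 3500 nM to 14500 nM.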

Compound 4, half-maximal inhibitory concentration: 780 nM
Compound 4: middle estimate off by 9.1-fold (0.96 log units), on the high side; the measured number lies below the stated range.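

In this assay, bromo in place of chloro on the core of compound 3 gives an 8.0-fold lower number from compound 3 to compound 4 (0.90 log units; beyond the scatter), a much larger step than the same change gave on the core of compound 1. The size of this step therefore did not carry over from one core to the other: the same change on two cores in this assay, a 1.1-fold higher number (0.06 log units; within the scatter) from compound 1 to compound 2 and an 8.0-fold lower number (0.90 log units; beyond the scatter) from compound 3 to compound 4, 9.2-fold (0.96 log units) apart, beyond the scatter of two such steps. This rests on just two pairs of compounds in one cell assay, so it shows that the step cannot be assumed to transfer between these cores, but not why the two steps differ or how the change would behave on any further core.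

The compounds shown carry only chloro or bromo at this place on the aromatic ring. On these data alone, it stays open how fluoro, iodo, methyl or an amine there would behave on either core.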